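This account rests on a few compounds, and the source may have more. Where it says the series, first, only, none or still open, it means among the compounds named here.

Measured so far, in a functional assay on MGC-803 cells (Homo sapiens) for cytotoxicity, read by MTT assay, with a stated time of 72 h; a higher number here means a weaker inhibitor, a lower number a stronger inhibitor:
Compound 1 `CC(C)=C1C(=O)N(c2ccc(Cl)cc2)N(c2ccc(Cl)cc2)C1=O`, which gives 39000 nM.
Compound 2 `COc1cc(C=C2C(=O)N(c3ccc(Cl)cc3)N(c3ccc(Cl)cc3)C2=O)cc(OC)c1OC`, which gives 17300 nM.
Compound 3 `O=C1C(=Cc2cccc(Cl)c2)C(=O)N(c2ccc(Cl)cc2)N1c1ccc(Cl)cc1`, which gives 14400 nM.

Among these three numbers compound 3 holds the lowest, though its gap to compound 2 lies within the usual scatter, so the two cannot be put in order; only compound 1 stands clearly apart, with a higher number beyond the scatter. The next compound, compound 4 `O=C1C(=Cc2ccccc2)C(=O)N(c2ccc(Cl)cc2)N1c1ccc(Cl)cc1`, has not yet been measured. It differs from compound 3 in one place: hydrogen in place of chloro on an aromatic carbon. Among the compounds with values here, no pair of measured compounds shows what this kind of change does, so there is no step to lean on. The author expects little to happen in this assay, at most a small rise in the number that may not clear the scatter, so the step of a 1.3-fold higher number from compound 3 to compound 4 (0.10 log units; within the scatter) is an estimate only. On that basis compound 4 is expected to give about 18000 nM, with a range from 9000 nM to 36000 nM.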

Compound 4, half-maximal inhibitory concentration: 27200 nM
Estimate against measurement, compound 4: 1.5-fold (0.18 log units) below; the range from low to high includes it.
By their numbers in this assay, from the lowest: compounds 3, 2, 4 and 1 (each within the scatter of the next, the first and the last beyond it).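

In this assay, within the data shown here, the first reading of hydrogen in place of chloro on this aromatic carbon, meta to a large group, is a 1.9-fold higher number from compound 3 to compound 4 (0.28 log units; within the scatter). The change from 3-chlorophenyl to phenyl therefore cannot be told apart from repeat-measurement noise, and these two compounds do not show that the chloro at this place matters for the read-out. Nothing on hand explains the size of this step.

The compounds shown leave open whether an amine or a carboxylic acid on this same aromatic carbon would move the number beyond the scatter. They also leave open whether hydrogen in place of the two chloro groups on the shared core would give a step of similar size.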